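Replacing the ethoxy of compound 1 with a boronic acid

The compounds below may be only part of what the source reports. "The series", "measured", "known", "first", "only" and "open" are said of these compounds alone.

Compound 1 `CCOc1ccc(C(=O)NNc2c(Br)cccc2Br)cc1`: > 100000 nM in a toxicity assay on MDCK cells (Canis lupus familiaris) for cytotoxicity, read by CCK-8 assay, with a stated time of 48 h; on this read-out lower numbers stand for higher toxicity in this test and higher numbers for lower toxicity in this test
Compound 2 `CCOc1ccc(C(=O)NNc2c(Br)cc(Br)cc2Br)cc1`: 54800 nM
Compound 3 `CCOc1ccc(C(=O)NNc2ccccc2Br)cc1`: > 100000 nM

Compound 1 stands at the upper limit of this assay, so its value is a limit and not a number; the same limit holds for two of the three measured compounds (the limit of > 100000 nM in this assay, at which 2 of the 3 values shown sit). Compound 4 `O=C(NNc1c(Br)cccc1Br)c1ccc(B(O)O)cc1` differs from compound 1 in one place: a group of 3 heavy atoms (1 boron, 2 oxygen; no ring) in place of a group of 3 heavy atoms (2 carbon, 1 oxygen; no ring), on an aromatic carbon. Among the measured compounds shown here, no measured step touches that position. The steps that exist, an at least 1.8-fold lower number from compound 1 to compound 2 (0.26 log units; that floor lies within the scatter) and a step that the two limits leave unreadable from compound 1 to compound 3, concern bromo groups on the other ring and say nothing readable about the ethoxy. Compound 4 is therefore expected to sit near the same limit as compound 1, a step that the limit leaves unreadable from compound 1 to compound 4. The estimate for compound 4 is 120000 nM, between 40000 nM and 300000 nM.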

Compound 4, half-maximal cytotoxic concentration: > 100000 nM
Compound 4: only a limit was reported; the forecaster's own chance of this, stated with the estimate: 60%; the middle value does not contradict the limit.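

In this assay compound 4 gives > 100000 nM, which is a limit and not a number, and compound 1 also stands at a limit, so no step between the two can be read: the limit of > 100000 nM in this assay, at which 3 of the 4 values shown sit.

The compounds shown leave open whether replacing ethoxy with this boron-bearing group changes the read-out at all.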